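Solubility in a Sulfonamide Series: Benzoyl to Boc-Prolyl

The compounds below may be only part of what the source reports. "The series", "measured", "known", "first", "only" and "open" are said of these compounds alone.

Measured compounds:
compound 1 `O=C(c1ccccc1)N1CCC(NS(=O)(=O)c2cc(S(=O)(=O)c3ccccc3)ccc2C(F)(F)F)CC1` — 12500 nM
compound 2 `CC(C)(C)OC(=O)N1CCC(CC(=O)N2CCC(NS(=O)(=O)c3cc(S(=O)(=O)c4ccccc4)ccc3C(F)(F)F)CC2)CC1` — 12500 nM

Of the compounds shown here, two have been measured in a physicochemical assay for solubility; a lower number here means a less soluble compound, a higher number a more soluble compound. Compound 1 gives 12500 nM in this assay, and compound 2 gives 12500 nM in this assay. The two values are level at the digits shown, so compound 1 stands with compound 2 within the scatter; no step between them has been worked out, and only their two values are known.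

Compound 3 `CC(C)(C)OC(=O)N1CCC[C@H]1C(=O)N1CCC(NS(=O)(=O)c2cc(S(=O)(=O)c3ccccc3)ccc2C(F)(F)F)CC1` has not yet been measured. It differs from compound 1 in one place: 1-(tert-butoxycarbonyl)pyrrolidin-2-yl in place of phenyl on a carbonyl carbon.

Compound 2 gives 12500 nM, level with compound 1 in this assay. On that basis the expected step is no change at the digits printed from compound 1 to compound 3 (within the scatter), no change beyond the scatter. Compound 3 is therefore estimated at 12500 nM in this assay, with a range from 5000 nM to 30000 nM.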

Compound 3, solubility: 25000 nM
Compound 3: middle estimate off by 2.0-fold (0.30 log units), on the low side; low and high end bracket the measured number.
By their numbers in this assay, from the lowest: compounds 1, 2 and 3 (each within the scatter of the next).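

For the compounds shown here, the step at this position reads a 2.0-fold higher number from compound 1 to compound 3 (0.30 log units; within the scatter) in this assay, the first step that can be read at a single place. On the carbonyl carbon, a phenyl with 6 heavy atoms and no hydrogen-bond acceptors gives way to a 1-(tert-butoxycarbonyl)pyrrolidin-2-yl with 12 heavy atoms, 2 hydrogen-bond acceptors and a defined stereocentre, and the result stays inside the usual scatter of this read-out. Nothing shown gives a measured reason for this result or ties it to any feature of either group.

The compounds shown leave open whether any group at this position would carry the number beyond the scatter. A free pyrrolidine amine without the tert-butoxycarbonyl group, or a carboxylic acid on a short chain, would test this.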